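This account rests on a few compounds, and the source may have more. Where it says the series, first, only, none or still open, it means among the compounds named here.

Compound 1, `Nc1nc(OCC(F)(F)F)c2ncn(/C=C3/CC3(CO)CO)c2n1`: in an ADME assay on MOLT-3 cells (Homo sapiens) for cytotoxicity, with a stated time of 7 days (on this read-out lower numbers stand for higher toxicity in this test and higher numbers for lower toxicity in this test), compound 1 gives > 20000 nM, which is a limit of the test and not a number.
Compound 2, `CC(C)CSc1nc(N)nc2c1ncn2/C=C1/CC1(CO)CO`: in this assay compound 2 gives "not determined" (no result reported).
Compound 3, `CCCCCCCCSc1nc(N)nc2c1ncn2/C=C1/CC1(CO)CO`: in this assay compound 3 gives > 20000 nM, again a limit of the test and not a number.

Compound 3 therefore stands on a limit alone. Of the two other values shown, one is also a limit and the other is an entry with no single number behind it, so nothing here ranks compound 3 against its neighbours. Two of the three values shown sit at the limit of > 20000 nM in this assay, at which 2 of the 3 values shown sit.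

The unmeasured compound 4, `CCCCOc1nc(N)nc2c1ncn2/C=C1/CC1(CO)CO`, differs from compound 3 in one place: butoxy in place of octylsulfanyl on an aromatic carbon. Going by the values given here, only one measured step touches this same position, a step that the two limits leave unreadable from compound 1 to compound 3, and since both of its ends are limits its size cannot be read. There is thus no readable step from which to expect a change in this assay beyond the scatter, and nothing shown points the butoxy group in either direction. The step from compound 3 to compound 4 is therefore expected to be a number no higher from compound 3 to compound 4 (the limit leaves the size open), with the result most likely once more a limit. For compound 4 the estimate in this assay is 20000 nM, in the range from 10000 nM to 40000 nM.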

Compound 4, half-maximal cytotoxic concentration: > 20000 nM
Compound 4: only a limit was reported; the forecaster's own chance of this, stated with the estimate: 85%; the middle value lies on the limit itself.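

In this assay compound 4 gives only a limit, so neither its step from compound 3 nor its step from compound 1 can be read. The values shown pile up at one point: the limit of > 20000 nM in this assay, at which 3 of the 4 values shown sit. The compounds shown leave open whether any of these groups on the shared core changes the toxicity in this test, and by how much.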